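The compounds below may be only part of what the source reports. "The series", "measured", "known", "first", "only" and "open" are said of these compounds alone.

In a functional assay on a cell-free system (Platelet, plasma, Homo sapiens) for inhibition (on this read-out lower numbers stand for stronger inhibition and higher numbers for weaker inhibition), compound 1 `O=C(Nc1cccc(OCc2ccc(-c3ccc(F)cc3)cc2)c1)C1CCNCC1` gives 35000 nM. Compound 2 `O=C(Nc1cccc(OCc2ccc(-c3c(F)cccc3F)cc2)c1)C1CCNCC1` stands at "not determined" (no result reported), so it has no place on the number scale. Compound 3 `O=C(Nc1cccc(OCc2ccc(-c3cc(F)cc(F)c3)cc2)c1)C1CCNCC1` differs from compound 2 in one group, 3,5-difluorophenyl in place of 2,6-difluorophenyl on an aromatic carbon. The size of this step cannot be measured from compound 2, which has no number. Within the data shown here, the only guide is compound 1 at 35000 nM, so a result in this assay close to that value, with no shift in either direction beyond the scatter, is expected. Compound 3 is estimated at 30000 nM, with an expected range of 10000 nM to 90000 nM.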

Compound 3, half-maximal inhibitory concentration: 27800 nM
Compound 3: the middle estimate sits 1.1-fold (0.03 log units) above what was measured; measured number inside the range.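

In this assay, 3,5-difluorophenyl in place of 4-fluorophenyl brings a 1.3-fold lower number from compound 1 to compound 3 (0.10 log units; within the scatter), so moving and adding fluorine on this ring leaves the read-out unchanged for this pair. The step from compound 2 to compound 3 cannot be read, as compound 2 has no number. No measurement at hand explains this flat result.

Still open, on these data alone, is whether 2,6-difluorophenyl, as in compound 2, would give a similar number. Also open, as far as these compounds go, is whether an amine or a carboxylic acid on this ring, in place of fluorine, would shift the read-out beyond the scatter.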